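Phenyl to 1H-pyrazol-3-yl on the carbonyl: lipophilicity notes

The source may report more compounds than this note shows. Statements on the series, on what has been measured and on what is new or still open speak of the compounds shown alone.

compound 1 `O=C(c1ccccc1)N1CCC(C(=O)N2N=CCC2c2ccccc2)CC1` — 4.4
compound 2 `O=C(c1ccccn1)N1N=CCC1c1ccccc1` — 2.4

Both numbers come from a physicochemical assay for lipophilicity, read by HPLC, measured as chromatographic lipophilicity, at pH 7.4; on this read-out higher numbers stand for higher lipophilicity and lower numbers for lower lipophilicity. Compound 1 is the higher of the two; compound 2 lies lower by a gap beyond the usual scatter. Compound 3 `O=C(c1cc[nH]n1)N1CCC(C(=O)N2N=CCC2c2ccccc2)CC1` is not yet measured. It differs from compound 1 in one place: 1H-pyrazol-3-yl in place of phenyl on a carbonyl carbon, the same change one bond further out reading benzoyl to (1H-pyrazol-3-yl)carbonyl. Within the data shown here, no measured pair shows this change, so the step is expected rather than known; a fall well beyond the scatter is expected, a number 1.80 log units lower from compound 1 to compound 3 (beyond the scatter). For compound 3 the estimate in this assay is 2.6, expected between 2 and 3.2.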

Compound 3, distribution coefficient: 2.4
Compound 3: the middle estimate sits 0.20 log units above what was measured; low and high end bracket the measured number.
By their numbers in this assay, from the lowest: compounds 2 and 3 (each within the scatter of the next); then compound 1.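

On this assay the carbonyl carbon of the shared core proves sensitive to the group it carries: 1H-pyrazol-3-yl in place of phenyl gives a number 2.00 log units lower from compound 1 to compound 3 (beyond the scatter) as a large step. Among these compounds, this is the first single-place change read, since compound 1 and compound 2 differ in more than one place. Nothing available bears on the cause of this step.

On these data alone, it remains open whether a 1-methyl-1H-pyrazol-3-yl group, with a methyl group in place of the ring hydrogen, would read closer to compound 1 or compound 3. As far as these compounds go, a morpholine on the same carbonyl carbon is equally open.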